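Compound 3 Leaves the Pyrazole for an Acetamidothiazole

This account rests on a few compounds, and the source may have more. Where it says the series, first, only, none or still open, it means among the compounds named here.

Measured compounds, in an ADME assay (liver) for metabolic stability, with Liver microsome (Homo sapiens) as the target, read by LC-MS, using microsomes and NADPH, with a stated time of 5 min, at 37 degrees C; a higher number here means faster removal of the compound, a lower number slower removal:
Compound 1 `CCCn1ncc(S(=O)(=O)N[C@H](C)c2nc3ccc(C(F)(F)F)cc3n2CC)c1C`: > 100 mL.min-1.g-1 (a limit)
Compound 2 `CCn1c([C@@H](C)NS(=O)(=O)c2cnn(C(C)C)c2C)nc2ccc(C(F)(F)F)cc21`: > 100 mL.min-1.g-1 (a limit)

Compound 2 has no number on this scale, only a limit of this assay. Its neighbour shares that position, as the limit of > 100 mL.min-1.g-1 in this assay, at which 2 of the 2 values shown sit, records. For the measured compounds named here, the one measured step is a step that the two limits leave unreadable from compound 1 to compound 2, with isopropyl in place of propyl on an aromatic nitrogen. That step has no readable size, and it touches a different part of the molecule from the change considered here.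

Compound 3 `CCn1c([C@@H](C)NS(=O)(=O)c2cnc(NC(C)=O)s2)nc2ccc(C(F)(F)F)cc21` carries 2-acetamido-1,3-thiazol-5-yl in place of 1-isopropyl-5-methyl-1H-pyrazol-4-yl on a sulfonyl sulfur. Going by the values given here, no measured step gives a size for this replacement, so the expectation rests on the structural change alone and remains loose. The isopropyl and methyl of the leaving group go, and a downward move is expected, although compound 3 could yet stay at the limit. The expected step is an at least 1.6-fold lower number from compound 2 to compound 3 (0.22 log units; that floor lies within the scatter). In this assay compound 3 is estimated at 60 mL.min-1.g-1, within an expected range of 20 mL.min-1.g-1 to 100 mL.min-1.g-1.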

Compound 3, intrinsic clearance in microsomes: 15 mL.min-1.g-1
Compound 3: the middle estimate sits 4.0-fold (0.60 log units) above what was measured; measured number below the stated range.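

In this assay, the replacement on the sulfonyl sulfur gives the first readable result at this position, with an at least 6.6-fold lower number from compound 2 to compound 3 (0.82 log units; beyond the scatter). The same replacement, set against the propyl-bearing pyrazole, gives an at least 6.6-fold lower number from compound 1 to compound 3 (0.82 log units; beyond the scatter), so both pyrazoles shown lie on the far side of a clear gap from the acetamidothiazole, and each step is a minimum that the true difference may exceed. The two pyrazole compounds alone could not show this, and the step between them cannot be read: the limit of > 100 mL.min-1.g-1 in this assay, at which 2 of the 3 values shown sit.

The exchange alters the ring and its substituents together, so the compounds shown do not tell whether the thiazole or the acetamido group carries the change, a question that a thiazole bearing an amine or a methyl in place of the acetamido group would address. They also leave open whether the lower number would hold on a different core, for example one with a nitrile in place of the trifluoromethyl group.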